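Swapping acetyl for hydroxy in a series at its limit

This account rests on a few compounds, and the source may have more. Where it says the series, first, only, none or still open, it means among the compounds named here.

Of the compounds shown here, three sharing one core have been tested so far in an ADME assay on HepG2 cells (Homo sapiens) for cytotoxicity, read by luminescence, with a stated time of 72 h (a higher number here means that more compound is needed for the effect, a lower number that less compound is needed), on the cells described there. Compound 1 (`CCOC(=O)c1c(-c2cccc(C)c2)[nH]c2cc(OC)ccc2c1=O`), with a methyl group, gives > 21500 nM as a limit and not a number. Compound 2 (`CCOC(=O)c1c(-c2cccc(OC)c2)[nH]c2cc(OC)ccc2c1=O`), with a methoxy group, gives > 21500 nM as a limit too. Compound 3 (`CCOC(=O)c1c(-c2cccc(C(C)=O)c2)[nH]c2cc(OC)ccc2c1=O`), with an acetyl group, gives > 21500 nM as a limit as well. Compound 3 thus has no number of its own (the limit of > 21500 nM in this assay, at which 3 of the 3 values shown sit).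

Compound 4 (`CCOC(=O)c1c(-c2cccc(O)c2)[nH]c2cc(OC)ccc2c1=O`) carries hydroxy in place of acetyl on an aromatic carbon. Three measured steps among these groups bear on this change: a step that the two limits leave unreadable from compound 1 to compound 3 and a step that the two limits leave unreadable from compound 2 to compound 3 and also a step that the two limits leave unreadable from compound 1 to compound 2 in the same kind of swap. None of them has a readable size, so no step beyond the scatter is expected in this assay in either direction. The expected step is (a step that the limit leaves unreadable from compound 3 to compound 4). For compound 4 the estimate is 25000 nM with an expected range from 9000 nM to 60000 nM and another limit is the likeliest report.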

Compound 4, half-maximal effective concentration: > 21500 nM
Compound 4: no number, only a limit; the forecaster's own chance of this, stated with the estimate: 80%; the middle value lies beyond the limit too.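

No new step can be read: compound 4 is again only a limit, so its steps from compound 1, compound 2 and compound 3 all stay unreadable. The compounds shown leave open what concentration any of them needs in this assay and whether methyl, methoxy, acetyl and hydroxy differ there at all.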